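Carbonyl substituent swap from compound 2 to compound 3

A few compounds are considered here, and "the series" means these few. Any claim that something is new, unique, unknown or untested is made for them only; others in the source may bear on it.

Values in a physicochemical assay for lipophilicity, read by HPLC, measured as chromatographic lipophilicity, at pH 7.4; a higher number here means a more lipophilic compound, a lower number a more polar compound:
- compound 1 `CC(C)(C)C(=O)N1N=CCC1C1CCCCC1`: 7.3
- compound 2 `CC(C)(CO)C(=O)N1N=CCC1c1ccccc1`: 3.4

Compound 2 stands lowest of the two in this assay, and the gap up to compound 1 lies beyond the usual scatter. Compound 3 `O=C(C1CCOCC1)N1N=CCC1c1ccccc1` carries oxan-4-yl in place of 1-(hydroxymethyl)-1-methylethyl on a carbonyl carbon. Among the measured compounds shown here, no measured pair shows this change alone, and the expectation is therefore loose: a small rise, possibly not beyond the scatter. The estimated change is a number 0.40 log units higher from compound 2 to compound 3 (beyond the scatter) in the upward direction. Compound 3 is expected at 3.8 (estimated range 3.1 to 4.5).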

Compound 3, distribution coefficient: 3.1
Compound 3: middle estimate off by 0.70 log units, on the high side; the range from low to high includes it.
By their numbers in this assay, from the lowest: compounds 3 and 2 (each within the scatter of the next); then compound 1.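

Among the compounds shown here, on the carbonyl carbon, oxan-4-yl in place of 1-(hydroxymethyl)-1-methylethyl reads in this assay as a number 0.30 log units lower from compound 2 to compound 3 (within the scatter) and this is the first step at this position. The entering group has 0 hydrogen-bond donors and one six-membered non-aromatic ring, against 1 donor and no ring in the leaving group, yet the two values stay within the scatter of each other. Nothing available accounts for this reading.

Open, from the compounds shown here alone, is how an amine or a carboxylic acid on this carbonyl carbon would read. Also open, going by these compounds, is whether the same swap reads alike on the core of compound 1.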